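The compounds below may be only part of what the source reports. "The series", "measured", "known", "first", "only" and "open" are said of these compounds alone.

Measured so far in an assay on isolated protein for inhibition of serine/threonine-protein kinase Chk2 (Homo sapiens); a higher number here means a weaker inhibitor, a lower number a stronger inhibitor:

Compound 1, `CC(C)(O)[C@H]1C[C@H](Nc2nc(-c3cc(F)ccc3O)nc3ccccc23)CN1`: 460 nM
Compound 2, `OC[C@H]1C[C@H](Nc2nc(-c3cc(F)ccc3O)nc3ccccc23)CN1`: 81 nM
Compound 3, `CC(C)(O)[C@@H]1CNC[C@H]1Nc1nc(-c2cc(F)ccc2O)nc2ccccc12`: 21 nM

Compound 3 stands lowest of the three, and its steps to the others are beyond the scatter: a 3.9-fold lower number from compound 2 to compound 3 (0.59 log units; beyond the scatter) and a 22-fold lower number from compound 1 to compound 3 (1.34 log units; beyond the scatter). Compounds 1 and 3 carry the same atoms joined differently; the difference between the two cores is 4-(1-hydroxy-1-methylethyl)pyrrolidin-3-yl in place of 5-(1-hydroxy-1-methylethyl)pyrrolidin-3-yl on a nitrogen on an aromatic ring.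

The change now in question, (hydroxymethyl in place of 1-hydroxy-1-methylethyl on a saturated ring carbon), gives compound 4, `OC[C@@H]1CNC[C@H]1Nc1nc(-c2cc(F)ccc2O)nc2ccccc12`. Among the compounds shown it occurs twice. Within the data shown here, its one measured precedent is hydroxymethyl in place of 1-hydroxy-1-methylethyl on a saturated ring carbon, which made a modest step: a 5.7-fold lower number from compound 1 to compound 2 (0.75 log units; beyond the scatter). The two places are not the same word for word: in the precedent the saturated ring carbon sits next to the ring nitrogen and two ring bonds from the ring atom that bears a large group, whereas in compound 3 it sits next to the ring atom that bears a large group and two ring bonds from the ring nitrogen. Among the measured compounds shown here, it is therefore the same kind of change, not the same change, and with only one precedent the transfer is uncertain.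

Compound 4 is expected to show a step of about a 2.6-fold lower number from compound 3 to compound 4 (0.42 log units; beyond the scatter), somewhat smaller than the precedent because the precedent a 5.7-fold lower number from compound 1 to compound 2 (0.75 log units; beyond the scatter) came from a differently placed carbon. The estimate for compound 4 in this assay is 8 nM, with a likely range from 2.5 nM to 25 nM.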

Compound 4, half-maximal inhibitory concentration: 37 nM
Beside the measured number, compound 4's estimate is 4.6-fold (0.67 log units) below it; measured number outside the range, above it.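

In this assay, hydroxymethyl in place of 1-hydroxy-1-methylethyl does not carry a fixed step from one core to the other: the same change on two cores in this assay, a 5.7-fold lower number (0.75 log units; beyond the scatter) from compound 1 to compound 2 and a 1.8-fold higher number (0.25 log units; within the scatter) from compound 3 to compound 4, 10-fold (1.00 log units) apart, beyond the scatter of two such steps

On the core of compound 3 the change gives a 1.8-fold higher number from compound 3 to compound 4 (0.25 log units; within the scatter), so the two groups are not told apart on a saturated ring carbon next to the ring atom that bears a large group, while the arrangement of the pyrrolidine substituents still registers in a 2.2-fold lower number from compound 2 to compound 4 (0.34 log units; beyond the scatter) and, with both groups differing, in a 12-fold lower number from compound 1 to compound 4 (1.09 log units; beyond the scatter). This rests on a single pair for each core, so it shows that the size of the step depends on the core but does not show what sets that dependence, and it gives no rule for any further core.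

Left open is how an aminomethyl group, a carboxylic acid or a longer chain such as 2-hydroxyethyl would read at this place on either core. Also open, on these data alone, is whether the gap between the two cores seen with hydroxymethyl would hold with any of those groups in its stead.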